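This account rests on a few compounds, and the source may have more. Where it says the series, first, only, none or still open, it means among the compounds named here.

Compound 3 `C[C@@H](O[C@H]1CN2C(=O)C=C(c3cc[n+]([O-])cc3)CC2[C@@H]1c1ccc(F)cc1)c1cc(C(F)(F)F)cc(C(F)(F)F)c1` gives the lowest number of the three measured compounds in an assay on CHO cells for displacement of a labelled ligand from Substance-P receptor (Homo sapiens) (on this read-out lower numbers stand for stronger inhibition and higher numbers for weaker inhibition), at 0.1 nM. Its closest neighbour is compound 1 `C[C@@H](O[C@H]1CN2C(=O)C=C(c3ccccc3)CC2[C@@H]1c1ccc(F)cc1)c1cc(C(F)(F)F)cc(C(F)(F)F)c1`, which in this assay gives 0.93 nM, and the gap is a 9.3-fold lower number from compound 1 to compound 3 (0.97 log units; beyond the scatter). Compound 2 `C[C@@H](O[C@H]1CN2C(=O)C=C(c3ccc(F)cc3)CC2[C@@H]1c1ccc(F)cc1)c1cc(C(F)(F)F)cc(C(F)(F)F)c1` gives 2 nM in this assay, and the step of a 20-fold lower number from compound 2 to compound 3 (1.30 log units; beyond the scatter) is the larger of the two. Between the two phenyl-bearing compounds the step of a 2.2-fold higher number from compound 1 to compound 2 (0.33 log units; beyond the scatter) is small by comparison.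

Compound 4 `C[C@@H](O[C@H]1CN2C(=O)C=C(c3cc[nH]c(=O)c3)CC2[C@@H]1c1ccc(F)cc1)c1cc(C(F)(F)F)cc(C(F)(F)F)c1` is built from the same atoms as compound 3 but joined differently: a group of 7 heavy atoms (5 carbon, 1 nitrogen, 1 oxygen; one six-membered aromatic ring with 1 hetero atom) in place of a group of 7 heavy atoms (5 carbon, 1 nitrogen, 1 oxygen; one six-membered aromatic ring with 1 hetero atom), on a double-bonded ring carbon. Among the measured compounds shown here, no measured step swaps one hetero-ring of this kind for another, so the two steps into compound 3 only show that this ring position tolerates a six-membered ring with one hetero atom and that such a ring has so far given the strongest result. Whether the ring that enters keeps that advantage cannot be read from the numbers shown. The expectation is therefore a modest rise toward the values of compound 1 and compound 2, but not all the way: the step from compound 3 is estimated at a 5.0-fold higher number from compound 3 to compound 4 (0.70 log units; beyond the scatter). In this assay compound 4 is expected to give about 0.5 nM, with a range from 0.1 nM to 3 nM.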

Compound 4, half-maximal inhibitory concentration: 0.27 nM
Estimate against measurement, compound 4: 1.9-fold (0.27 log units) above; the range from low to high includes it.
By their numbers in this assay, from the lowest: compound 3; then compound 4; then compound 1; then compound 2.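

In this assay, rejoining the same atoms into the ring of compound 4, which counts a hydrogen-bond donor that the ring of compound 3 lacks, gives a 2.7-fold higher number from compound 3 to compound 4 (0.43 log units; beyond the scatter), so this position responds to how the ring atoms are arranged and not only to which atoms are present. The gain over the carbon-only rings nevertheless survives the rearrangement, with a 3.4-fold lower number from compound 1 to compound 4 (0.54 log units; beyond the scatter) and a 7.4-fold lower number from compound 2 to compound 4 (0.87 log units; beyond the scatter), and in all four compounds shown, both rings with one hetero atom give lower numbers than both carbon-only rings, with no compound going against this. No measurement shown explains these differences.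

The compounds shown leave open whether the hydrogen on the ring nitrogen of compound 4 matters, which a methyl group in its place on the same ring would help to test. They also leave open whether the low numbers depend on having a six-membered aromatic ring at this position at all, or would persist with a ring holding two nitrogen atoms, or with an open chain ending in an amine or a carboxylic acid.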